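The source may hold more compounds than are shown below. What is called first, only, known or untested is meant among the compounds shown, and "the series" means these compounds.

Compound 1 `Cc1cc(NNC(=O)Nc2cc(Cl)nc(Cl)c2)ncc1N(C)C`: 3600 nM
Compound 2 `Cc1cc(C#N)nc(NNC(=O)Nc2cc(Cl)nc(Cl)c2)c1`: > 6600 nM

Of the compounds shown here, two built on the same core have been tested in a functional assay on CHO cells for antagonist activity at sphingosine 1-phosphate receptor 2 (Homo sapiens), read by fluorescence and calcium flux, with a stated time of 3 min; on this read-out lower numbers stand for stronger inhibition and higher numbers for weaker inhibition. Compound 1 gives 3600 nM. For compound 2 the assay reports only a limit, > 6600 nM, so no number is known for it. Within the data shown here, compound 2 thus stands at the limit of > 6600 nM in this assay, at which 1 of the 2 values shown sits, and no step between compound 1 and compound 2 can be stated; the two values show only that compound 1 reached a measurable inhibition while compound 2 did not.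

Compound 3 `Cc1cc(NNC(=O)Nc2cc(Cl)nc(Cl)c2)nc(-c2cnn(C)c2)c1` differs from compound 2 in a single place: 1-methyl-1H-pyrazol-4-yl in place of cyano on an aromatic carbon. Among the measured compounds shown here, no measured step covers a change of this kind, so any expectation rests on the limit alone. Because compound 2 sits at the limit of > 6600 nM in this assay, at which 1 of the 2 values shown sits, the size of the change cannot be anchored to a number; the expectation is that compound 3 moves toward stronger inhibition by an at least 1.6-fold lower number from compound 2 to compound 3 (0.21 log units; that floor lies within the scatter), though the range is wide. Compound 3 is estimated at 4000 nM, expected to fall between 1000 nM and 20000 nM.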

Compound 3, half-maximal inhibitory concentration: > 2100 nM
Compound 3: only a limit was reported; the forecaster's own chance of this, stated with the estimate: 40%; the middle value lies beyond the limit too.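

Compound 2 and compound 3 each carry only a limit in this assay, so no step can be read for the change from cyano to 1-methyl-1H-pyrazol-4-yl between them. The compounds shown leave open how strongly compound 2 and compound 3 actually inhibit, and whether that change shifts inhibition at all.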